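A few compounds are considered here, and "the series" means these few. Any claim that something is new, unique, unknown or untested is made for them only; others in the source may bear on it.

For the measured compounds named here, compound 2 `CC(=O)c1ccccc1OC1CCN(c2ccc(-n3ccnc3)nn2)CC1` in an assay on microsomes from liver for inhibition of acyl-CoA desaturase 1 (Rattus norvegicus) (a lower number here means a stronger inhibitor, a higher number a weaker inhibitor), gives 34 nM, the higher of the two numbers measured so far; compound 1 `OCc1nnc(-c2ccc(N3CCC(Oc4ccccc4C(F)(F)F)CC3)nn2)s1` in this assay gives 3.2 nM, a gap beyond the scatter. Going by the values given here, no pair that differs in one place has been measured, so the effect of any single change is not yet known from this series. Compound 3 `c1cc(OC2CCN(c3ccc(-n4ccnc4)nn3)CC2)c2cc[nH]c2c1` remains to be measured; it differs from compound 2 by 1H-indol-4-yl in place of 2-acetylphenyl on an oxygen on a saturated carbon. The step of a 1.4-fold lower number from compound 2 to compound 3 (0.13 log units; within the scatter) is expected to be small, toward a lower number, and may well fall within the scatter. For compound 3 the estimate in this assay is 25 nM, with a range of 8 nM to 80 nM.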

Compound 3, half-maximal inhibitory concentration: 162 nM
For compound 3 the middle estimate is 6.5-fold (0.81 log units) below the measured one; the whole stated range lies below it.
By their numbers in this assay, from the lowest: compound 1; then compound 2; then compound 3.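

For the compounds shown here, on the oxygen on a saturated carbon, the group is not interchangeable in this assay: 1H-indol-4-yl in place of 2-acetylphenyl gives a 4.8-fold higher number from compound 2 to compound 3 (0.68 log units; beyond the scatter) and so provides the first single-place reading. This step favours 2-acetylphenyl, and the hydrogen-bond donor entering with the indole travels with the weaker number, though one pair cannot separate that feature from the rest of the swap. No measurement on hand explains the step. 

Open, from the compounds shown here alone, is how a plain phenyl or 2-methoxyphenyl would read at this position, and whether the same swap behaves alike on the core of compound 1.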